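Notes on the aryl ether variation and tolerated concentration

A few compounds are considered here, and "the series" means these few. Any claim that something is new, unique, unknown or untested is made for them only; others in the source may bear on it.

The series is followed in an ADME assay on PBMC cells (Homo sapiens) for cytotoxicity; a higher number here means that more compound is tolerated, a lower number that less compound is tolerated. Compound 1 `Cc1cccc(OC(c2ccc(Br)cc2)C2CCN(C(C)CCNC(=O)c3c(Cl)cncc3Cl)CC2)n1` gives 6500 nM in this assay. Compound 2 `Cc1cccc(OC(c2ccc(C(F)(F)F)cc2)C2CCN(C(C)CCNC(=O)c3c(Cl)cncc3Cl)CC2)n1` gives 6700 nM, and of the two numbers shown these two sit within the scatter of each other, so neither stands apart. Compound 3 `CCO/N=C(/c1ccc(Br)cc1)C1CCN(C(CC)CCNC(=O)c2c(C)cc[n+]([O-])c2C)CC1` is reported only as a limit of the assay, > 177000 nM, as recorded in the limit of > 177000 nM in this assay, at which 1 of the 3 values shown sits. Among the compounds with values here, the one measured step between neighbours, a 1.0-fold higher number from compound 1 to compound 2 (0.01 log units; within the scatter), concerns a group on an aromatic carbon and lies within the scatter.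

Compound 4 `CC(CCNC(=O)c1c(Cl)cncc1Cl)N1CCC(C(Oc2ccccc2)c2ccc(Br)cc2)CC1` is not yet measured. It differs from compound 1 by phenyl in place of 6-methylpyridin-2-yl on an oxygen on a saturated carbon. Within the data shown here, no measured step touches this position, and the one step known, a 1.0-fold higher number from compound 1 to compound 2 (0.01 log units; within the scatter), sits elsewhere and within the scatter, so nothing in the numbers so far points in either direction for the exchange of (6-methylpyridin-2-yl)oxy for phenoxy. The step of a 1.1-fold higher number from compound 1 to compound 4 (0.03 log units; within the scatter) is therefore expected to stay within the scatter. Compound 4 is estimated at 7000 nM, with a range from 2500 nM to 20000 nM.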

Compound 4, half-maximal cytotoxic concentration: 31700 nM
Compound 4: middle estimate off by 4.5-fold (0.66 log units), on the low side; the measured number lies above the stated range.
By their numbers in this assay, from the lowest: compounds 1 and 2 (each within the scatter of the next); then compound 4. At a limit, above all of these: compound 3.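

The exchange of 6-methylpyridin-2-yl for phenyl on an oxygen on a saturated carbon gives the only step shown beyond the scatter in this assay, namely a 4.9-fold higher number from compound 1 to compound 4 (0.69 log units; beyond the scatter). The trifluoromethyl for bromo exchange on an aromatic carbon stays within the scatter, at a 1.0-fold higher number from compound 1 to compound 2 (0.01 log units; within the scatter), so on these two pairs the tolerated concentration responds to the group on the oxygen and not to that one. The change removes the ring nitrogen and the methyl together, and nothing measured here gives a reason for the step.

Whether the ring nitrogen or the methyl accounts for the step stays open, and an unsubstituted pyridin-2-yl and a methylphenyl on the same oxygen would separate the two. On these data alone, how an amine or a carboxylic acid on the phenyl would read in this assay also remains open.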